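Methoxy to dimethylamino on the shared core

The source may report more compounds than this note shows. Statements on the series, on what has been measured and on what is new or still open speak of the compounds shown alone.

Measured so far in a functional assay on A2780 cells (Homo sapiens) for inhibition, read by sulforhodamine B assay; a lower number here means a stronger inhibitor of growth, a higher number a weaker inhibitor of growth:
- compound 1 `FC(F)(F)c1ccc(-c2ccc(-c3ccc(-c4nc5ccccc5[nH]4)cc3)cc2)cc1` gives (100000 nM)
- compound 2 `COc1ccc(-c2ccc(-c3ccc(-c4nc5ccccc5[nH]4)cc3)cc2)cc1` gives (100000 nM)

Compound 2 stands level with compound 1 and serves as the starting point for the next step. Compound 3 `CN(C)c1ccc(-c2ccc(-c3ccc(-c4nc5ccccc5[nH]4)cc3)cc2)cc1` carries dimethylamino in place of methoxy on an aromatic carbon, para to a large group (dimethylamino in place of methoxy on an aromatic carbon). Among the compounds with values here, one measured step bears on this change, a swap of methoxy in place of trifluoromethyl on an aromatic carbon (no change at the digits printed from compound 1 to compound 2 (within the scatter)). That step lies within the scatter, though a single pair is thin evidence. No step beyond the scatter is therefore expected in this assay, and no direction is favoured. The estimated step is small (a 1.3-fold lower number from compound 2 to compound 3 (0.10 log units; within the scatter)). For compound 3 the expected value is 80000 nM in the estimate, with an estimated range from 30000 nM to 100000 nM around it.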

Compound 3, concentration for 50% growth inhibition: 100000 nM
Compound 3: the middle estimate sits 1.3-fold (0.10 log units) below what was measured; the measured number falls inside the stated range.
By their numbers in this assay, from the lowest: compounds 1, 2 and 3 (each within the scatter of the next).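

In this assay, a third group on this aromatic carbon, para to a large group, leaves the reading where it stood: no change at the digits printed from compound 2 to compound 3 (within the scatter) and no change at the digits printed from compound 1 to compound 3 (within the scatter). Dimethylamino now stands with methoxy and trifluoromethyl at the same printed number, so the flat result at this position no longer rests on a single pair of compounds. No measurement at hand offers an explanation for this flat result.

Still open, from the compounds shown here alone, is whether any group at this position can separate from these three, for instance a carboxylic acid, a primary amine or a longer chain. Also open, going by these compounds, is whether a change elsewhere on the shared core would move the number at all, since all three compounds differ only at this one place.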